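The source may report more compounds than this note shows. Statements on the series, on what has been measured and on what is new or still open speak of the compounds shown alone.

In an ADME assay on MT4 cells (Homo sapiens) for cytotoxicity (on this read-out lower numbers stand for higher toxicity in this test and higher numbers for lower toxicity in this test), three compounds with a shared core have been measured so far. Compound 1 `CC[C@H]1CC[C@H](c2ccc(NC(=S)Nc3cccc(C(F)(F)F)c3)cc2)CC1` gives 39000 nM, compound 2 `FC(F)(F)c1cccc(NC(=S)Nc2ccc(I)cc2)c1` gives 10000 nM, and compound 3 `Fc1ccc(NC(=S)Nc2cccc(C(F)(F)F)c2)cc1` gives 31000 nM. Compound 3 therefore belongs to the upper pair of the three. Its gap to the other member of that pair is small, a 1.3-fold lower number from compound 1 to compound 3 (0.10 log units; within the scatter), while its gap to the remaining compound is larger, a 3.1-fold higher number from compound 2 to compound 3 (0.49 log units; beyond the scatter).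

The next compound, compound 4 `CCOC(=O)c1ccc(NC(=S)Nc2cccc(C(F)(F)F)c2)cc1`, has ethoxycarbonyl in place of fluoro on an aromatic carbon. The three measured steps all change the group at this same place, so they offer the best guide. Going from 4-ethylcyclohexyl to fluoro gave a 1.3-fold lower number from compound 1 to compound 3 (0.10 log units; within the scatter), and going from 4-ethylcyclohexyl to iodo gave a 3.9-fold lower number from compound 1 to compound 2 (0.59 log units; beyond the scatter). Even the largest of these steps is only modest, and ethoxycarbonyl itself has not yet been tested in this series. A large change therefore seems unlikely, and the direction is uncertain, with compound 2 showing that a modest drop is possible at 10000 nM. The expected step is small and stays within the scatter, a 1.4-fold lower number from compound 3 to compound 4 (0.15 log units; within the scatter). For compound 4, the estimate in this assay is 22000 nM, with an expected range from 9000 nM to 50000 nM.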

Compound 4, half-maximal cytotoxic concentration: 23000 nM
The estimate for compound 4 lay 1.0-fold (0.02 log units) below the measured number, and the stated range covers the measured number.
By their numbers in this assay, from the lowest: compound 2; then compounds 4, 3 and 1 (each within the scatter of the next).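

At this place, on an aromatic carbon para to a large group, ethoxycarbonyl brings in more heavy atoms than fluoro, a double bond outside the aromatic ring and hydrogen-bond acceptors, yet the outcome in this assay is only a 1.3-fold lower number from compound 3 to compound 4 (0.13 log units; within the scatter) and so shows no real change. Set against the much bigger 4-ethylcyclohexyl group, the ester also gives a difference that cannot be told from noise, a 1.7-fold lower number from compound 1 to compound 4 (0.23 log units; within the scatter), so three quite different groups now sit together in this test. Iodo is the one group that stands apart, with a 2.3-fold higher number from compound 2 to compound 4 (0.36 log units; beyond the scatter), so the only clear difference at this place so far belongs to compound 2 rather than to the largest group.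

Nothing in the data explains why compound 2 differs from the other three. Bromo or chloro at this place would help show whether the lower number is peculiar to iodo, and a carboxylic acid or an amine would show whether the numbers stay this close with groups of another kind.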